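The compounds below may be only part of what the source reports. "The series", "measured", "known", "first", "only" and "open" are said of these compounds alone.

Among the compounds with values here, in an ADME assay on HaCaT cells (Homo sapiens) for inhibition, read by sulforhodamine B assay, with a stated time of 48 h (a higher number here means a weaker inhibitor of growth, a lower number a stronger inhibitor of growth), compound 3 `CC(C)(C)NCc1c(C(=O)O)nn(-c2ccc(Cl)cc2)c1-c1ccc(F)cc1` gives 28700 nM, the only single number among the measured compounds. Compound 2 `CC(C)(C)NCc1c(C(=O)O)nn(-c2ccccc2)c1-c1ccc(Cl)cc1` gives > 652000 nM, which is a limit of the assay. Compound 1 `CCOC(=O)c1nn(-c2ccc(Cl)cc2)c(-c2ccc(Cl)cc2)c1CNC(C)(C)C` has entries that disagree, 2900 nM; > 519000 nM (2 entries). Among the entries of compound 1, one is a limit of the assay. Compound 4 `CC(C)(C)NCc1c(C(=O)O)nn(-c2ccc(Cl)cc2)c1-c1ccc(Cl)cc1` differs from compound 3 by chloro in place of fluoro on an aromatic carbon, on the 4-fluorophenyl group, which becomes 4-chlorophenyl. Within the data shown here, no measured pair shows this change, so the expectation in this assay is for no shift beyond the scatter. The expected step is a 1.0-fold higher number from compound 3 to compound 4 (0.02 log units; within the scatter). For compound 4 the estimated value is 30000 nM, with an expected range of 6000 nM to 250000 nM.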

Compound 4, concentration for 50% growth inhibition: 87500 nM
The estimate for compound 4 lay 2.9-fold (0.46 log units) below the measured number, and the stated range covers the measured number.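

In this assay, the 4-fluorophenyl to 4-chlorophenyl change gives a 3.0-fold higher number from compound 3 to compound 4 (0.48 log units; beyond the scatter), the first sign that the number responds to the halogen at this position, para to a large group. Chloro in place of hydrogen on an aromatic carbon gives an at least 7.4-fold lower number from compound 2 to compound 4 (0.87 log units; beyond the scatter). Compound 2 enters that step with a limit, not a number.

From the compounds shown here alone, whether a bromo or a methoxy group at this position would shift the number further stays open. The step between the carboxylic acid of compound 4 and the ethyl ester of compound 1 cannot be read, because compound 1 has entries that disagree: the several entries of compound 1 in this assay, 2900 nM; > 519000 nM (2 entries)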